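Moving away from trifluoromethyl: what to expect of compound 4

The compounds below may be only part of what the source reports. "The series", "measured", "known", "first", "only" and "open" are said of these compounds alone.

Of the compounds shown here, three sharing one core have been measured in a functional assay on HepG2 cells (Homo sapiens) for inhibition, read by MTT assay (a lower number here means a stronger inhibitor, a higher number a weaker inhibitor), so far, and they differ in a single group on an aromatic carbon. Compound 1 (`COc1cc2ncnc(Nc3ccc(NC(=O)c4cccc(C)c4)cc3)c2cc1OC`) carries methyl and gives 7500 nM as its value. Compound 2 (`COc1cc2ncnc(Nc3ccc(NC(=O)c4cccc(I)c4)cc3)c2cc1OC`) carries iodo and gives 28000 nM as its value. Compound 3 (`COc1cc2ncnc(Nc3ccc(NC(=O)c4cccc(C(F)(F)F)c4)cc3)c2cc1OC`) carries trifluoromethyl and gives 83000 nM as its value, the highest number of the three, which makes it the weakest inhibitor among them.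

Compound 4 (`COc1cc2ncnc(Nc3ccc(NC(=O)c4cc(F)ccc4Br)cc3)c2cc1OC`) has 2-bromo-5-fluorophenyl in place of 3-(trifluoromethyl)phenyl on a carbonyl carbon. Within the data shown here, no measured compound carries this entering group, so the evidence is indirect. The step of an 11-fold higher number from compound 1 to compound 3 (1.04 log units; beyond the scatter) is large, the step of a 3.0-fold higher number from compound 2 to compound 3 (0.47 log units; beyond the scatter) is modest, and the step of a 3.7-fold higher number from compound 1 to compound 2 (0.57 log units; beyond the scatter) is also modest. In both steps that involve trifluoromethyl, the compound carrying it has the higher number, so leaving that group behind is expected to lower the number, though probably not all the way to the level of compound 1. The estimated change in this assay is a 3.0-fold lower number from compound 3 to compound 4 (0.47 log units; beyond the scatter) as a modest step. Compound 4 is expected at 28000 nM with a range of 9000 nM to 85000 nM in this estimate.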

Compound 4, half-maximal inhibitory concentration: 22000 nM
The estimate for compound 4 lay 1.3-fold (0.10 log units) above the measured number, within the range that was stated.
By their numbers in this assay, from the lowest: compound 1; then compounds 4 and 2 (each within the scatter of the next); then compound 3.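

In this assay the swap of 3-(trifluoromethyl)phenyl for 2-bromo-5-fluorophenyl gives a 3.8-fold lower number from compound 3 to compound 4 (0.58 log units; beyond the scatter) and so shows that this position tolerates a phenyl group carrying two halogens, not only a phenyl group carrying a single group. Against the 3-iodophenyl of compound 2, the same group gives a 1.3-fold lower number from compound 2 to compound 4 (0.10 log units; within the scatter) and the two cannot be told apart, so quite different halogen-bearing phenyl groups can end up at the same level here. The 3-methylphenyl group still gives the lowest number of the four, with a 2.9-fold higher number from compound 1 to compound 4 (0.47 log units; beyond the scatter) as the gap, so this new halogen pattern does not close the distance to compound 1.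

As far as these compounds go, compound 4 changes bromine and fluorine together, so the share of each stays open, as does the effect of a phenyl group carrying bromine alone or fluorine alone, or of an amine or a carboxylic acid on this ring. Nothing shown here gives a measured reason for the order of these groups.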